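Amine Substituent Variation on the Shared Nucleoside Core

The source may hold more compounds than are shown below. What is called first, only, known or untested is meant among the compounds shown, and "the series" means these compounds.

Measured compounds:
compound 1 `CN(Cc1ncnc2c1ncn2[C@@H]1O[C@H](CO)[C@@H](O)[C@H]1O)c1ccccc1` — 3400 nM
compound 2 `CSCc1ncnc2c1ncn2[C@@H]1O[C@H](CO)[C@@H](O)[C@H]1O` — 5000 nM

Both values come from a functional assay on HL-60 cells (Homo sapiens) for inhibition, read by XTT assay, with a stated time of 72 h; on this read-out lower numbers stand for stronger inhibition and higher numbers for weaker inhibition. In this assay compound 1 gives 3400 nM, the lowest of the two numbers shown; the nearest is compound 2, and the step is a 1.5-fold higher number from compound 1 to compound 2 (0.17 log units; within the scatter), so the two stand within the scatter of each other.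

Compound 3 `CN(Cc1ccccc1)Cc1ncnc2c1ncn2[C@@H]1O[C@H](CO)[C@@H](O)[C@H]1O` is not yet measured. Compared with compound 1 it carries benzyl in place of phenyl on an amine nitrogen. No measured step alters the same place: the only step shown exchanges the whole methyl(phenyl)amino group for methylsulfanyl and stays within the scatter. Nothing in the data therefore points to a step beyond the scatter for compound 3, and a step of about no change at the digits printed from compound 1 to compound 3 (within the scatter) is expected. Compound 3 is estimated at 3400 nM in this assay, with a range from 1200 nM to 10000 nM.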

Compound 3, half-maximal inhibitory concentration: 2400 nM
Compound 3: middle estimate off by 1.4-fold (0.15 log units), on the high side; the measured number falls inside the stated range.
By their numbers in this assay, from the lowest: compounds 3, 1 and 2 (each within the scatter of the next, the first and the last beyond it).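

In this assay the exchange of phenyl for benzyl on the amine nitrogen gives a 1.4-fold lower number from compound 1 to compound 3 (0.15 log units; within the scatter) and so does not separate the two groups at this position. Among the compounds shown here, the change from methylsulfanyl to benzyl(methyl)amino gives a 2.1-fold lower number from compound 2 to compound 3 (0.32 log units; beyond the scatter) and is the first modest step beyond the scatter. Compound 1, with methyl(phenyl)amino, stands within the scatter of both compound 2 and compound 3, so this step does not set amine substituents as a whole apart from methylsulfanyl.

Still open, on these data alone, is whether a phenethyl group on the amine nitrogen, or a hydroxyl group in place of the whole substituent, would give a larger step. No measurement shown here bears on the reason for either step.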